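The source may hold more compounds than are shown below. What is called first, only, known or untested is meant among the compounds shown, and "the series" means these compounds.

Compound 1 `O=C(/C=C/c1coc2cc(O)ccc2c1=O)NCc1ccccc1` was tested in an ADME assay on HepG2 2.2.15 cells (Homo sapiens) for cytotoxicity, read by MTT assay, with stated times of 48 h and 9 days (a lower number here means that less compound is tolerated, a higher number that more compound is tolerated), where compound 1 gives 436000 nM, the highest of the two numbers seen so far. The nearest is compound 2 `COc1ccc2c(=O)c(/C=C/C(=O)NCc3ccccc3)coc2c1`, which in this assay gives 376000 nM; that step, a 1.2-fold lower number from compound 1 to compound 2 (0.06 log units; within the scatter), changes little. Compound 3 `Cc1ccccc1NC(=O)/C=C/c1coc2cc(O)ccc2c1=O` differs from compound 1 by 2-methylphenyl in place of benzyl on an amide-type nitrogen. Going by the values given here, no measured step touches this change, since the only one available concerns an oxygen on an aromatic ring instead of the amide-type nitrogen. The expected step is therefore none beyond the scatter, that is a 1.1-fold lower number from compound 1 to compound 3 (0.04 log units; within the scatter). Compound 3 is estimated to give 400000 nM in this assay, within 150000 nM to 1000000 nM.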

Compound 3, half-maximal cytotoxic concentration: 374000 nM
Estimate against measurement, compound 3: 1.1-fold (0.03 log units) above; the measured number falls inside the stated range.
By their numbers in this assay, from the lowest: compounds 3, 2 and 1 (each within the scatter of the next).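

Replacing benzyl with 2-methylphenyl on the amide-type nitrogen is the first change shown on this side of the molecule, and in this assay it gives a 1.2-fold lower number from compound 1 to compound 3 (0.07 log units; within the scatter). Swapping these two groups, which have the same count of heavy atoms, therefore leaves the number within the scatter. No measurement here offers an explanation for this result. Going by these compounds, whether a plain phenyl, a carboxylic acid or a longer chain on this nitrogen would give a step beyond the scatter remains open. So does whether 2-methylphenyl and the methyl on the aromatic oxygen would behave the same together.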